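Amide aryl swap and cytotoxicity in a bicyclic amide series

The compounds below may be only part of what the source reports. "The series", "measured", "known", "first", "only" and "open" are said of these compounds alone.

Measured compounds:
compound 1 `CC(C)n1ccc2c(C(=O)Nc3ccccn3)cc(-c3cccs3)nc21`: > 200000 nM
compound 2 `CC(C)n1ncc2c(C(=O)Nc3ccccn3)cc(-c3ccsc3)nc21`: 25000 nM
compound 3 `CC(C)n1ncc2c(C(=O)Nc3ccc(F)cc3)cc(-c3ccsc3)nc21`: > 200000 nM

In an ADME assay on LLC-MK2 cells (Macaca mulatta) for cytotoxicity, read by spectrophotometry and crystal violet staining, with a stated time of 4 days (on this read-out higher numbers stand for lower toxicity in this test and lower numbers for higher toxicity in this test), compound 2 gives 25000 nM. For compound 1 the value > 200000 nM is a limit of this assay, not a number. For compound 3 the value > 200000 nM is likewise a limit, not a number. How the core of compound 1 differs from the core of compound 2 is not broken down here.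

The change from compound 2 to compound 3 is 4-fluorophenyl in place of pyridin-2-yl on an amide-type nitrogen. It brings an at least 8.0-fold higher number from compound 2 to compound 3 (0.90 log units; beyond the scatter), so the compound with the 4-fluorophenyl group reads as less toxic in this assay.

Compound 4 `CC(C)n1ccc2c(C(=O)Nc3ccc(F)cc3)cc(-c3cccs3)nc21` is not yet measured in this assay. It arises from compound 1 by 4-fluorophenyl in place of pyridin-2-yl on an amide-type nitrogen. This is the same change as from compound 2 to compound 3, at the same place, on an amide-type nitrogen whose other neighbours are a carbonyl carbon; it occurs in two pairs among the compounds shown.

The expected step is a number no higher from compound 1 to compound 4 (the limit leaves the size open), smaller than the earlier one, because the limit of > 200000 nM in this assay, at which 2 of the 3 values shown sit, leaves no room for the number to rise further as a reported value. Compound 4 is therefore expected at 200000 nM in this assay, within 100000 nM to 400000 nM, and most probably reported again as a limit rather than a number.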

Compound 4, half-maximal cytotoxic concentration: > 200000 nM
Compound 4: no number, only a limit; the forecaster's own chance of this, stated with the estimate: 85%; the middle value sits exactly at the limit.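

In this assay compound 4 gives > 200000 nM, a limit and not a number. No step from compound 1 to compound 4 can be read, because both compounds stand at the same limit: the limit of > 200000 nM in this assay, at which 3 of the 4 values shown sit.

The compounds shown leave open whether 4-fluorophenyl in place of pyridin-2-yl lowers toxicity in this test on the core of compound 1, as it does on the core of compound 2.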